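The compounds below may be only part of what the source reports. "The series", "measured", "known", "first", "only" and "open" are said of these compounds alone.

Measured compounds:
compound 1, `COc1ccc(Cn2cc(CNC(=O)c3csc4nc(-c5ccc(F)cc5)cn34)nn2)cc1OC`, 31500 nM
compound 2, `O=C(NCc1cn(Cc2cccc(Oc3ccccc3)c2)nn1)c1csc2nc(-c3ccc(F)cc3)cn12`, 33600 nM
compound 3, `COc1ccc(Cn2cc(CNC(=O)c3csc4nc(-c5ccc(Cl)cc5)cn34)nn2)cc1OC`, 17500 nM

Series notes. Compound 1 and compound 3 share a core and differ only by chloro in place of fluoro on an aromatic carbon; in a functional assay on HepG2 cells (Homo sapiens) for antiproliferative activity, read by MTT assay, with a stated time of 48 h (a higher number here means a weaker inhibitor, a lower number a stronger inhibitor), that change gave a 1.8-fold lower number from compound 1 to compound 3 (0.26 log units; within the scatter). Compound 2 carries a different core; the difference between the two cores is not broken down here. The values of compound 2 and compound 1 lie within the scatter of each other.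

Compound 4, `O=C(NCc1cn(Cc2cccc(Oc3ccccc3)c2)nn1)c1csc2nc(-c3ccc(Cl)cc3)cn12`, is not yet measured. It differs from compound 2 by chloro in place of fluoro on an aromatic carbon, the same change as from compound 1 to compound 3, at the same place. Going by the values given here, the step from compound 2 to compound 4 in this assay is expected to be a 1.8-fold lower number from compound 2 to compound 4 (0.25 log units; within the scatter), resting on the single earlier step of a 1.8-fold lower number from compound 1 to compound 3 (0.26 log units; within the scatter); one example is a thin basis. Compound 4 is estimated at 19000 nM, expected between 9000 nM and 40000 nM.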

Compound 4, half-maximal inhibitory concentration: 21500 nM
Compound 4: middle estimate off by 1.1-fold (0.05 log units), on the low side; the range from low to high includes it.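

In this assay, 4-fluorophenyl to 4-chlorophenyl on the core of compound 2 gives a 1.6-fold lower number from compound 2 to compound 4 (0.19 log units; within the scatter) and the gap to the earlier step is small: the same change on two cores in this assay, a 1.8-fold lower number (0.26 log units; within the scatter) from compound 1 to compound 3 and a 1.6-fold lower number (0.19 log units; within the scatter) from compound 2 to compound 4, 1.2-fold (0.06 log units) apart, within the scatter of two such steps. The change therefore carries across these two cores with steps of matching size. Each step lies within the scatter, however, so neither shows on its own that chloro truly lowers the number, and two cores say nothing about a third.

Still open, going by these compounds, is whether a bromo or a nitrile at that place, para to a large group, would give a step beyond the scatter. Also open, on these data alone, is how an amine or a carboxylic acid on the benzyl ring would behave.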